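Trading a Fluorohydroxyphenyl Ring for a Trimethoxyphenyl Ring

The source may hold more compounds than are shown below. What is called first, only, known or untested is meant among the compounds shown, and "the series" means these compounds.

Three compounds share one core and differ only in the aryl ring on a double-bonded chain carbon. In a functional assay on MCF7 cells (Homo sapiens) for antiproliferative activity, read by sulforhodamine B assay, with a stated time of 48 h (a higher number here means a weaker inhibitor, a lower number a stronger inhibitor), compound 1 `COc1cccc(/C=C/C(=O)C(=Cc2ccc(F)cc2)C(=O)/C=C/c2cccc(OC)c2OC)c1OC` gives 1830 nM, compound 2 `COc1cc(OC)c(C=C(C(=O)/C=C/c2cccc(OC)c2OC)C(=O)/C=C/c2cccc(OC)c2OC)c(OC)c1` gives 720 nM, and compound 3 `COc1cccc(/C=C/C(=O)C(=Cc2ccc(O)c(F)c2)C(=O)/C=C/c2cccc(OC)c2OC)c1OC` gives 300 nM, the lowest of the three numbers. The steps of a 6.1-fold lower number from compound 1 to compound 3 (0.79 log units; beyond the scatter) and a 2.4-fold lower number from compound 2 to compound 3 (0.38 log units; beyond the scatter) both set compound 3 apart. Compound 4 `COc1cccc(/C=C/C(=O)C(=Cc2ccc(OC)c(OC)c2OC)C(=O)/C=C/c2cccc(OC)c2OC)c1OC` carries the change (2,3,4-trimethoxyphenyl in place of 3-fluoro-4-hydroxyphenyl on a double-bonded chain carbon bound to a double-bonded chain carbon). The step of a 2.4-fold lower number from compound 2 to compound 3 (0.38 log units; beyond the scatter) bears most directly: it runs the same kind of exchange in reverse, with a different methoxy pattern, and points to a higher number. For compound 4 a step of a 2.3-fold higher number from compound 3 to compound 4 (0.37 log units; beyond the scatter) is expected in this assay. The estimate for compound 4 is 700 nM, within 250 nM to 2000 nM.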

Compound 4, half-maximal inhibitory concentration: 380 nM
For compound 4 the middle estimate is 1.8-fold (0.27 log units) above the measured one, and the stated range covers the measured number.
By their numbers in this assay, from the lowest: compounds 3, 4 and 2 (each within the scatter of the next, the first and the last beyond it); then compound 1.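

Compound 3's 3-fluoro-4-hydroxyphenyl ring can give way to 2,3,4-trimethoxyphenyl, which has no hydrogen-bond donor, with a 1.3-fold higher number from compound 3 to compound 4 (0.10 log units; within the scatter) staying within the scatter. Moving the methoxy groups also shows no clear effect, with a 1.9-fold lower number from compound 2 to compound 4 (0.28 log units; within the scatter) within the scatter, whereas a 4.8-fold lower number from compound 1 to compound 4 (0.68 log units; beyond the scatter) lies beyond it. No available data explain these numbers. As far as these compounds go, it remains open how a ring carrying an amine or a carboxylic acid would behave at this double-bonded chain carbon. The separate contributions of the hydroxyl and the fluorine also remain unresolved.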